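This account rests on a few compounds, and the source may have more. Where it says the series, first, only, none or still open, it means among the compounds named here.

Compound 1, `COc1ccc(-c2nc3cc(Cl)c(Cl)cc3[nH]2)c(N)c1`, in an ADME assay on MDBK cells (Bos taurus) for cytotoxicity, read by MTT assay, with a stated time of 96 h (on this read-out lower numbers stand for higher toxicity in this test and higher numbers for lower toxicity in this test), gives 6500 nM.
Compound 2, `CCN(CC)CC(=O)Nc1ccc(-c2nc3cc(C(F)(F)F)ccc3n2C)cc1`, in this assay gives 57000 nM.
Compound 3, `O=C(CCl)Nc1ccc(-c2nc3cc(C(F)(F)F)ccc3[nH]2)cc1`, in this assay gives 17000 nM.

Of these three, compound 2 stands at the highest number, and its distance to compound 3 as well as to compound 1 is beyond the usual scatter of repeated measurements, so compound 2 is the least toxic of the three in this assay. Compound 4, `CC(=O)Nc1ccc(-c2nc3cc(C(F)(F)F)ccc3n2C)cc1`, has not yet been measured. It differs from compound 2 in one place: hydrogen in place of diethylamino on a saturated chain carbon bound to a carbonyl carbon. Within the data shown here, no pair of measured compounds here differs in exactly this way, so no measured step can be read across directly. Compound 3, which carries a different acetamido substitution and an unmethylated core, gives a lower number than compound 2, and that is the only hint available. The expectation is that compound 4 will show a modest step from compound 2 toward a lower number, a 1.6-fold lower number from compound 2 to compound 4 (0.21 log units; within the scatter), of a size that may not clearly exceed the scatter. On that basis the estimate for compound 4 in this assay is 35000 nM, with a range from 12000 nM to 100000 nM.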

Compound 4, half-maximal cytotoxic concentration: 46000 nM
Estimate against measurement, compound 4: 1.3-fold (0.12 log units) below, within the range that was stated.
By their numbers in this assay, from the lowest: compound 1; then compound 3; then compounds 4 and 2 (each within the scatter of the next).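

In this assay, the replacement of diethylamino by hydrogen on the saturated chain carbon bound to a carbonyl carbon gives a 1.2-fold lower number from compound 2 to compound 4 (0.09 log units; within the scatter), the first step read directly at this position. Across this pair, removing a group of five heavy atoms, a basic description of nothing more than its size and atoms being all that is known here, leaves the two numbers within the scatter of each other, so this test does not separate the diethylamino and acetamido ends of these two compounds. Nothing measured in the compounds shown accounts for this result.

Compound 3 carries chloro at this chain carbon but differs from compound 4 in more than one place, so the effect of that group on its own stays unresolved. On these data alone, what a morpholine, a carboxylic acid or a longer chain at this carbon would give in this assay remains open, and so does whether this one pair speaks for the core of compound 1 or any other core.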